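This account rests on a few compounds, and the source may have more. Where it says the series, first, only, none or still open, it means among the compounds named here.

Measured compounds:
- compound 1, `COc1ccc(C(=O)NCc2ccc(CNS(=O)(=O)c3ccccc3)cc2)cc1`, 1000 nM
- compound 2, `Cc1ccc(S(=O)(=O)NCc2ccc(CNC(=O)c3ccccc3Cl)cc2)cc1`, 10 nM
- compound 3, `O=C(NCc1ccc(CNS(=O)(=O)c2ccccc2)cc1)c1cccc(Cl)c1`, 1000 nM

All three were tested in an assay on MDA-MB-231 cells for binding affinity to C-X-C chemokine receptor type 4 (Homo sapiens), read by immunofluorescence and microscopy, with stated times of 10 min and 30 min; on this read-out lower numbers stand for an effect already at smaller amounts and higher numbers for an effect only at larger amounts of compound. Compound 2 stands lowest of the three numbers: compound 1 and compound 3 both sit at higher values, and both gaps lie beyond the scatter. Compound 2 also differs from compounds 1 and 3 in two places at once, since it carries a methyl group on the sulfonyl-bearing phenyl ring as well as the (2-chlorophenyl)carbonyl, so the numbers cannot tell which of the two features carries the gap.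

The unmeasured compound 4, `Cc1ccc(S(=O)(=O)NCc2ccc(CNC(=O)c3cccc(F)c3)cc2)cc1`, keeps the methylphenyl sulfonamide of compound 2 and changes only the aryl on the carbonyl carbon: 3-fluorophenyl in place of 2-chlorophenyl on a carbonyl carbon. Among the measured compounds shown here, the one measured step at the same position, no change at the digits printed from compound 1 to compound 3 (within the scatter), was flat, which suggests that swapping one substituted phenyl for another on the carbonyl carbon need not move the number much. For the measured compounds named here, that step, however, was taken on the weaker pair, and no step shows what a change at this position does when the methylphenyl sulfonamide is present.

Compound 4 is therefore expected to land between the two groups, with a step of a 10-fold higher number from compound 2 to compound 4 (1.00 log units; beyond the scatter) in this assay, giving an estimate of 100 nM with a range from 10 nM to 1000 nM.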

Compound 4, effective concentration (reported as EC, without a stated level of effect): 1 nM
Estimate against measurement, compound 4: 100-fold (2.00 log units) above; the measured number lies below the stated range.
By their numbers in this assay, from the lowest: compound 4; then compound 2; then compounds 1 and 3 (each within the scatter of the next).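

With the methylphenyl sulfonamide held fixed, 3-fluorophenyl in place of 2-chlorophenyl on a carbonyl carbon gives, in this assay, a 10-fold lower number from compound 2 to compound 4 (1.00 log units; beyond the scatter), so a change at this position can clearly move the number. Among the compounds shown here, the only earlier step here, no change at the digits printed from compound 1 to compound 3 (within the scatter), showed no such movement, but it swapped a different pair of aryl groups and was taken with a plain phenyl on the sulfonyl group, so the flat result does not hold for every change at this position. No measurement of any other kind is available to explain the size of the new step.

Going by these compounds, it remains open whether the lower number follows the fluorine itself or the 3-position of the substituent, a question that 3-chlorophenyl and 2-fluorophenyl on the carbonyl carbon, each paired with the methylphenyl sulfonamide, could help to settle. On these data alone, it is equally open how the number would respond if an amine or a carboxylic acid replaced the halogen on this ring.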